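The source may hold more compounds than are shown below. What is called first, only, known or untested is meant among the compounds shown, and "the series" means these compounds.

Measured in an ADME assay on MRC5 cells (Homo sapiens) for inhibition, with a stated time of 72 h; on this read-out higher numbers stand for an effect only at larger amounts of compound and lower numbers for an effect already at smaller amounts:
Compound 1 `COc1cccc(OC)c1C(=O)Nc1c[nH]nc1C(=O)NCCCOC(C)C` gives > 50000 nM, which is a limit of the assay and not a number.
Compound 2 `COc1cccc(OC)c1C(=O)Nc1c[nH]nc1C(=O)NCCCN(C)C` gives > 50000 nM, also a limit of the assay.

On the numbers shown, compound 2 sits at the limit of > 50000 nM in this assay, at which 2 of the 2 values shown sit, so its true value is known only as a limit. Among the measured compounds shown here, the only measured step is a step that the two limits leave unreadable from compound 1 to compound 2; with both of its ends at the limit, its size cannot be read, and no measured step tells how much a change on the chain at this position matters. Compound 3 `COc1cccc(OC)c1C(=O)Nc1c[nH]nc1C(=O)NC1CCCCC1` differs from compound 2 by cyclohexyl in place of 3-(dimethylamino)propyl on an amide-type nitrogen. With both measured values at the limit and no readable step, no shift beyond the scatter in this assay can be drawn from the data, and compound 3 is expected to remain at the limit as well. The step that the limit leaves unreadable from compound 2 to compound 3 is therefore expected to be small. Compound 3 is estimated at 70000 nM, between 20000 nM and 250000 nM, and most likely reported again as a limit.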

Compound 3, half-maximal effective concentration: 35000 nM
The estimate for compound 3 lay 2.0-fold (0.30 log units) above the measured number, and the stated range covers the measured number.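

In this assay compound 3 is the first of the compounds shown to give a number and not a limit, so cyclohexyl on the amide-type nitrogen gives a readable value where neither open chain did. The change reads as an at least 1.4-fold lower number from compound 2 to compound 3 (0.15 log units; that floor lies within the scatter), and set against the ether chain it reads as an at least 1.4-fold lower number from compound 1 to compound 3 (0.15 log units; that floor lies within the scatter). Both are only floors, so the true size of each step may be small or much larger, since the other end of each is not a number: the limit of > 50000 nM in this assay, at which 2 of the 3 values shown sit.

The compounds shown leave open whether the ring itself matters or only the loss of the chain, which a plain hexyl chain or a cyclopentyl or phenyl group on the same nitrogen could separate. They also do not tell whether a ring carrying an amine, such as piperidin-4-yl, would behave like cyclohexyl.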